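The source may report more compounds than this note shows. Statements on the series, on what has been measured and on what is new or still open speak of the compounds shown alone.

Measured so far:
- compound 1, `CCOC(=O)CCCC/C=C(\c1ccccc1)c1cccnc1`: 600 nM
- compound 2, `O=C(O)C(CCC/C=C(\c1ccccc1)c1cccnc1)Sc1ccccc1`: 33 nM
- compound 3, `O=C(O)CCCC/C=C(/CCCc1ccccc1)c1cccnc1`: 65 nM

These three compounds share a core in which a double-bonded chain carbon carries a pyridine-bearing group, and they were compared in an assay (Equus caballus) for inhibition of Thromboxane-A synthase (Homo sapiens), using microsomes; on this read-out higher numbers stand for weaker inhibition and lower numbers for stronger inhibition. Compound 1 gives 600 nM, the highest of the three numbers, so it is the weakest inhibitor of the set; compound 3 stands nearest with 65 nM, and compound 2 furthest with 33 nM, both gaps lying beyond the usual scatter. Compound 2 and compound 3 each end their chain in a free carboxylic acid, whereas compound 1 ends in an ethyl ester.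

Compound 4, `CC(C)(CCCC/C=C(\c1ccccc1)c1cccnc1)C(=O)O`, has not yet been tested in this assay. It differs from compound 1 in one place: 1-carboxy-1-methylethyl in place of ethoxycarbonyl on a saturated chain carbon, four bonds along the chain from a double-bonded chain carbon. The change thus swaps the ester of compound 1 for a free acid, the feature that compound 2 and compound 3 also carry. Because compound 2 gives 33 nM and compound 3 gives 65 nM, both well under the number for compound 1, the expectation for compound 4 is a step toward stronger inhibition, of about a 10-fold lower number from compound 1 to compound 4 (1.00 log units; beyond the scatter), clearly beyond the scatter. Compound 4 is therefore estimated at 60 nM, within a range from 15 nM to 250 nM.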

Compound 4, half-maximal inhibitory concentration: 45 nM
The estimate for compound 4 lay 1.3-fold (0.12 log units) above the measured number; the measured number falls inside the stated range.
By their numbers in this assay, from the lowest: compounds 2, 4 and 3 (each within the scatter of the next); then compound 1.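

In this assay, putting 1-carboxy-1-methylethyl in place of ethoxycarbonyl on this saturated chain carbon gives a 13-fold lower number from compound 1 to compound 4 (1.12 log units; beyond the scatter), a large step toward stronger inhibition. Within the data shown here, until now, no two measured compounds differed in only one place, so this is the first direct evidence that changing this chain end, from an ester to a free acid with a branched carbon, can by itself shift the number well beyond the scatter. No measurement shown here explains how the change produces a step of this size.

The change is also a bundle: the ethyl ester is lost, a hydrogen-bond donor is gained, and two methyl groups enter on the carbon that carries the carboxyl group, so this one step cannot divide the gain among these features. Among these compounds, an unbranched carboxylic acid on the same core and chain would help separate the contribution of the acid from that of the methyl groups, while a primary amide or a tetrazole at this place would show whether a carboxylic acid is the only end group that gives such a step.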